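A few compounds are considered here, and "the series" means these few. Any claim that something is new, unique, unknown or untested is made for them only; others in the source may bear on it.

For the measured compounds named here, in a functional assay on a cell-free system (plasma, Homo sapiens) for inhibition, with Plasma (Rattus norvegicus) as the target (on this read-out lower numbers stand for stronger inhibition and higher numbers for weaker inhibition), compound 1 `COc1c(C)cnc(COc2ccc3c(N4CCNCC4)cc(=O)oc3c2C)c1C` gives 3300 nM and compound 2 `CSCCOc1ccc2c(N3CCNCC3)cc(=O)oc2c1C` gives 1500 nM, the lower of the only two numbers measured so far. Compound 3 `Cc1c(OCCOc2ccccc2)ccc2c(N3CCNCC3)cc(=O)oc12` keeps the shared core of compound 2 and alters only the end of the chain: phenoxy in place of methylsulfanyl on a saturated chain carbon, two bonds along the chain from an oxygen on an aromatic ring. Phenoxy thus stands in place of methylsulfanyl on a saturated chain carbon, two bonds along the chain from an oxygen on an aromatic ring. Going by the values given here, one measured step bears on this: a 2.2-fold lower number from compound 1 to compound 2 (0.34 log units; beyond the scatter). That modest step swapped a ring-bearing chain end for one with methylsulfanyl, and compound 3 brings a ring back, though a different one. A similarly modest move towards weaker inhibition therefore seems likely, but a single step is thin support. The expected change is a 1.5-fold higher number from compound 2 to compound 3 (0.17 log units; within the scatter). For compound 3 the estimated value is 2200 nM, with a range of 800 nM to 6000 nM.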

Compound 3, half-maximal inhibitory concentration: 9400 nM
Beside the measured number, compound 3's estimate is 4.3-fold (0.63 log units) below it; measured number outside the range, above it.
By their numbers in this assay, from the lowest: compound 2; then compound 1; then compound 3.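

Phenoxy in place of methylsulfanyl at the end of this chain brings a 6.3-fold higher number from compound 2 to compound 3 (0.80 log units; beyond the scatter) in this assay. That moves the number further than the earlier step did, which was a 2.2-fold lower number from compound 1 to compound 2 (0.34 log units; beyond the scatter). A ring at the chain end does not settle the number by itself, as the two ring-bearing ends also differ from each other with a 2.8-fold higher number from compound 1 to compound 3 (0.45 log units; beyond the scatter) while both stand above compound 2. Nothing measured here gives a reason for these differences.

Still open, from the compounds shown here alone, is whether the higher number of compound 3 follows from the benzene ring or from the oxygen that links it to the chain. Phenylsulfanyl at the same place would separate those two parts, and an amine at the chain end would show how a very different group reads here.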